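Replacing 3-methoxyphenyl with 4-fluorophenyl on a shared core

The source may report more compounds than this note shows. Statements on the series, on what has been measured and on what is new or still open speak of the compounds shown alone.

In a toxicity assay on THP-1 cells (Homo sapiens) for inhibition (on this read-out higher numbers stand for lower toxicity in this test and lower numbers for higher toxicity in this test), compound 2 `COc1cccc(-c2cnc(NC(=O)c3ccc(F)cc3)n2C)c1` gives > 100000 nM, which is a limit of the assay and not a number. Compound 3 `Cn1cc(-c2ccccc2)nc1NC(=O)c1ccc(F)cc1` gives > 50000 nM, which is also a limit. Of the three measured compounds, only compound 1 `Cn1c(-c2ccc(Br)cc2)cnc1NC(=O)c1ccc(F)cc1` has a true number, 46000 nM.

Compound 4 `Cn1c(-c2ccc(F)cc2)cnc1NC(=O)c1ccc(F)cc1` differs from compound 2 by having 4-fluorophenyl in place of 3-methoxyphenyl on an aromatic carbon. Among the measured compounds shown here, only one measured step bears on this change: an at least 2.1-fold higher number from compound 1 to compound 2 (0.33 log units; beyond the scatter). That step replaced 4-bromophenyl with 3-methoxyphenyl, and the new change leaves 3-methoxyphenyl again. For the measured compounds named here, the 4-fluorophenyl group is closer in name and pattern to the 4-bromophenyl of compound 1, at 46000 nM, so a move back towards that number is expected, though no measured compound carries this group. The estimated change is modest and towards a lower number, an at least 1.6-fold lower number from compound 2 to compound 4 (0.22 log units; that floor lies within the scatter). For compound 4 the expected value is 60000 nM, with an estimated range from 25000 nM to 130000 nM.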

Compound 4, half-maximal cytotoxic concentration: > 100000 nM
Compound 4: only a limit was reported; the forecaster's own chance of this, stated with the estimate: 40%; at least 1.6-fold (0.22 log units) between middle value and limit.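

Among the compounds shown here, the only readable step among the earlier compounds swapped 4-bromophenyl for 3-methoxyphenyl, changing the substituent and its ring pattern together, whereas here only the halogen on 4-substituted phenyl changes. In this assay, that single exchange gives an at least 2.1-fold higher number from compound 1 to compound 4 (0.33 log units; beyond the scatter), so the higher number at this position does not depend on a methoxy group or on moving the substituent. The step between the 3-methoxyphenyl and 4-fluorophenyl compounds cannot be read, because compound 2 and compound 4 both stop at the same limit: the limit of > 100000 nM in this assay, at which 2 of the 4 values shown sit.

Going by these compounds, how far either compound lies past that limit remains open, and so does any order between them. Also open, on these data alone, is whether 4-chlorophenyl, or a phenyl ring bearing an amine or a carboxylic acid, would keep the number high at this position.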